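Restoring the Urea in Place of a Benzamide

This account rests on a few compounds, and the source may have more. Where it says the series, first, only, none or still open, it means among the compounds named here.

Compound 2 `COc1cc(-c2nn(-c3cccc(NC(=O)c4ccccc4)c3)cc2-c2ccncc2)ccc1Cl` stands only at a limit in a functional assay on OVCAR-4 cells (Homo sapiens) for inhibition, read by sulforhodamine B assay, with a stated time of 48 h; on this read-out lower numbers stand for stronger inhibition of growth and higher numbers for weaker inhibition of growth: compound 2 gives > 100000 nM, which is an assay limit and not a number. Compound 1 `COc1cc(-c2nn(-c3cccc(NC(=O)Nc4cccc(C(F)(F)F)c4)c3)cc2-c2ccncc2)ccc1Cl` gives 2100 nM in this assay. Within the data shown here, the one measured step, an at least 47-fold higher number from compound 1 to compound 2 (1.67 log units; beyond the scatter), pairs with this change, and its exact size cannot be told because of the limit of > 100000 nM in this assay, at which 1 of the 2 values shown sits. Compound 3 `COc1cc(-c2nn(-c3cccc(NC(=O)Nc4ccc(Cl)c(Cl)c4)c3)cc2-c2ccncc2)ccc1Cl` has not yet been measured in this assay; it carries (3,4-dichlorophenyl)amino in place of phenyl on a carbonyl carbon. This change brings back an arylamino group on the carbonyl carbon, the kind of group whose removal produced the step from compound 1 to compound 2, so a large fall in this assay is expected, estimated as an at least 50-fold lower number from compound 2 to compound 3 (1.69 log units; beyond the scatter). Compound 3 is therefore expected to come near where compound 1 sits, and its estimate in this assay is 2000 nM, with a range from 600 nM to 8000 nM.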

Compound 3, concentration for total growth inhibition: > 50000 nM
Compound 3 ended at the assay's limit; the forecaster's own chance of this, stated with the estimate: 5%; at least 25-fold (1.39 log units) between middle value and limit.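

In this assay compound 3 gives > 50000 nM, which is a limit of the assay and not a number. So an arylamino group on the carbonyl carbon does not by itself bring a readable value, and the ring it carries counts: 3,4-dichlorophenyl in place of 3-(trifluoromethyl)phenyl on the amide-type nitrogen gives an at least 23-fold higher number from compound 1 to compound 3 (1.37 log units; beyond the scatter), leaving compound 1 as the only one of the three with a value that is not a limit. The step from compound 2 to compound 3 cannot be read, and how far compound 3 truly stands from compound 2 stays unknown: the limit of > 50000 nM in this assay, at which 1 of the 3 values shown sits.

The compounds shown leave open how a plain phenylamino group would read on the same carbonyl carbon. They also leave open whether a 3-chlorophenyl or a 4-chlorophenyl group on the amide-type nitrogen would stay at a limit or give a number.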